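This account rests on a few compounds, and the source may have more. Where it says the series, first, only, none or still open, it means among the compounds named here.

The series rests on compound 1 `N#C/C(=C\c1c(-c2ccccc2)[nH]c2ccccc12)C(=O)c1ccccc1`, which in a functional assay on MT4 cells (Homo sapiens) for antiproliferative activity, read by MTT assay, with a stated time of 96 h (a lower number here means that less compound is needed, a higher number that more compound is needed for the effect), gives 500 nM. Of the two compounds that return a number in this assay, compound 1 stands lowest. Compound 2 `CCOC(=O)/C(=C/c1c(-c2ccccc2)[nH]c2ccccc12)C(=O)c1ccccc1` carries an ethyl ester where compound 1 carries the nitrile; in this assay compound 2 gives 7000 nM, a gap beyond the usual scatter. Compound 3 `N#C/C(=C\c1c[nH]c2ccccc12)S(=O)(=O)c1ccccc1`, which lacks the phenyl on the core and bears a sulfonyl rather than a carbonyl, is reported in this assay only as > 100000 nM; that value is a limit of the assay and not a number, and it is the limit of > 100000 nM in this assay, at which 1 of the 3 values shown sits.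

The unmeasured compound 4 `N#C/C(=C\c1c(-c2ccccc2)[nH]c2ccccc12)C(=O)Nc1ccc(Cl)cc1` differs from compound 1 by (4-chlorophenyl)amino in place of phenyl on a carbonyl carbon. For the measured compounds named here, no measured pair in the set shows this kind of change, so the expectation rests on the neighbours alone. Compound 2, at 7000 nM, shows that altering the chain next to the carbonyl can cost activity beyond the scatter, while compound 1 at 500 nM sets the anchor. A modest upward step is expected, a 3.0-fold higher number from compound 1 to compound 4 (0.48 log units; beyond the scatter). For compound 4 the estimate in this assay is 1500 nM, with a plausible range from 300 nM to 8000 nM.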

Compound 4, half-maximal effective concentration: 1700 nM
For compound 4 the middle estimate is 1.1-fold (0.05 log units) below the measured one, and the stated range covers the measured number.
By their numbers in this assay, from the lowest: compound 1; then compound 4; then compound 2. At a limit, above all of these: compound 3.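

At a carbonyl carbon whose other neighbour is the double-bonded chain carbon, (4-chlorophenyl)amino in place of phenyl gives a 3.4-fold higher number from compound 1 to compound 4 (0.53 log units; beyond the scatter) in this assay. For the compounds shown here, this is the first step in the set that can be read at this place, since it changes one group while the shared core and the nitrile stay as they are. It shows that the larger group, which brings an amide hydrogen that phenyl lacks, costs a modest but real amount of activity and still leaves compound 4 with a measured number rather than a limit, though nothing measured here bears on what lies behind the step.

The change alters two things at once, the amino link and the chlorine on the ring, and the compounds shown do not separate them: phenylamino without the chlorine would be the group to tell them apart. Also open, as far as these compounds go, is how this carbonyl carbon would respond to a simple alkylamine such as dimethylamino, to a morpholine, or to a benzylamino group with its longer chain.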